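This account rests on a few compounds, and the source may have more. Where it says the series, first, only, none or still open, it means among the compounds named here.

Measured in a functional assay on MDA-MB-231 cells (Homo sapiens) for antiproliferative activity, read by MTT assay, with a stated time of 48 h; on this read-out higher numbers stand for weaker inhibition and lower numbers for stronger inhibition:
- compound 1 `COc1ccc(N(C)c2ccnc(Cl)n2)cc1OCCBr`: 6620 nM
- compound 2 `COc1ccc(N(C)c2cc(C)nc(C)n2)cc1`: 3650 nM
- compound 3 `Cc1cc(N(C)c2ccc([Se]C#N)cc2)nc(C)n1`: 614 nM

In this assay, compound 3 has the lowest number of the three, clearly under both other values. The next analogue is compound 4 `C[Se]c1ccc(N(C)c2cc(C)nc(C)n2)cc1`, which keeps the selenium of compound 3 and carries a different group on it: methyl in place of cyano on a selenium. In short, methyl in place of cyano on a selenium.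

Among the measured compounds shown here, only one measured step bears on this change: a 5.9-fold lower number from compound 2 to compound 3 (0.77 log units; beyond the scatter). It is a modest step beyond the scatter, and it ended at the cyano-bearing selenium group. Compound 1 differs from the others in several places and gives no clean comparison. For the measured compounds named here, no measured pair isolates the cyano group itself, so the inference is weak. Losing the cyano group is expected to give back part of that gain, with the number landing between those of compound 3 and compound 2.

The expected change is a 2.4-fold higher number from compound 3 to compound 4 (0.39 log units; beyond the scatter), a modest rise. For compound 4 the estimated value is 1500 nM, with an expected range of 350 nM to 5000 nM.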

Compound 4, half-maximal inhibitory concentration: 321 nM
For compound 4 the middle estimate is 4.7-fold (0.67 log units) above the measured one, outside the stated range (below it).
By their numbers in this assay, from the lowest: compounds 4 and 3 (each within the scatter of the next); then compounds 2 and 1 (each within the scatter of the next).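

In this assay, a 1.9-fold lower number from compound 3 to compound 4 (0.28 log units; within the scatter) shows that methyl and cyano on a selenium cannot be told apart here, so the cyano group is not required for the gain seen with compound 3. The pair with compound 2 differs only in selenium for oxygen under the same methyl, and an 11-fold lower number from compound 2 to compound 4 (1.06 log units; beyond the scatter) ties a large step to the selenium atom itself, which the earlier step could not do, as it changed both the atom and the group on it. No measurement of any property of these groups accompanies the result.

Open, going by these compounds, is whether sulfur in place of selenium under the same methyl gives a number nearer that of compound 2 or compound 4. Also open, on these data alone, is how a longer chain, such as ethyl or propyl, or an amine-bearing chain on the selenium would read in this assay.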